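From 4-chlorophenyl to 4-bromophenyl: the next halogen step

The compounds below may be only part of what the source reports. "The series", "measured", "known", "first", "only" and "open" are said of these compounds alone.

In a functional assay on MCF7 cells (Homo sapiens) for antiproliferative activity, read by sulforhodamine B assay, with a stated time of 48 h (on this read-out higher numbers stand for weaker inhibition and lower numbers for stronger inhibition), compound 1 (`COc1cc(C2=CC(c3ccc(F)cc3)NC(=S)N2)cc(OC)c1OC`) gives 125 nM and compound 2 (`COc1cc(C2=CC(c3ccc(Cl)cc3)NC(=S)N2)cc(OC)c1OC`) gives 120 nM. Compound 2 therefore stands level with compound 1, as the two values lie within the scatter of each other. The next change leads to compound 3 (`COc1cc(C2=CC(c3ccc(Br)cc3)NC(=S)N2)cc(OC)c1OC`): bromo in place of chloro on an aromatic carbon. This is bromo in place of chloro on an aromatic carbon, para to a large group. Among the measured compounds shown here, one measured step bears on it, chloro in place of fluoro at the same place: a 1.0-fold lower number from compound 1 to compound 2 (0.02 log units; within the scatter), within the scatter. A single step is thin evidence, but it gives no reason to expect a shift beyond the scatter in this assay. The estimate for compound 3 is 120 nM, with an expected range of 65 nM to 220 nM. The expected step is no change at the digits printed from compound 2 to compound 3 (within the scatter), within the scatter.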

Compound 3, half-maximal inhibitory concentration: 77 nM
Compound 3: middle estimate off by 1.6-fold (0.19 log units), on the high side; the range from low to high includes it.
By their numbers in this assay, from the lowest: compounds 3, 2 and 1 (each within the scatter of the next).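

With compound 3, the position para to a large group now carries three halogens. In this assay the bromo compound gives a 1.6-fold lower number from compound 2 to compound 3 (0.19 log units; within the scatter) and a 1.6-fold lower number from compound 1 to compound 3 (0.21 log units; within the scatter) and both steps are printed as within the scatter, so neither separates bromo from the lighter halogens. Fluoro, chloro and bromo on this aromatic carbon are therefore not told apart by this read-out, a statement that earlier rested on the single fluoro and chloro pair; no measurement at hand offers an explanation for the values seen here.

Open, going by these compounds, is whether iodo would stay level with these three halogens. Also open, on these data alone, is whether a group other than a halogen at this place, such as methoxy, an amine or a carboxylic acid, would give a step beyond the scatter.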